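This account rests on a few compounds, and the source may have more. Where it says the series, first, only, none or still open, it means among the compounds named here.

Compound 2 `CN(CCCCc1ccccc1)C1CCc2ccccc2C(O)C1` carries a methyl on its amine nitrogen and a saturated chain that ends in an aromatic ring. In an assay on membranes from liver for displacement of a labelled ligand from Sigma intracellular receptor 2 (Rattus norvegicus), read by scintillation counting, with a stated time of 120 min (a higher number here means a weaker inhibitor, a lower number a stronger inhibitor), compound 2 gives 66 nM. For the measured compounds named here, its only measured neighbour, compound 1 `OC1CC(NCCCCc2ccccc2)CCc2ccccc21`, bears a hydrogen on that nitrogen instead; in this assay compound 1 gives 100 nM, and the step of a 1.5-fold lower number from compound 1 to compound 2 (0.18 log units; within the scatter) does not rise above the scatter of the measurement, so the two numbers stand on equal footing. Compound 3 `CN(CCCc1ccccc1)C1CCc2ccccc2C(O)C1` keeps the methyl and shortens the chain: phenyl in place of benzyl on a saturated chain carbon, three bonds along the chain from an amine nitrogen. Going by the values given here, the one measured step concerns the substituent on the nitrogen, not the chain, so it offers no guide to this change, and nothing in the two measured compounds points in either direction. The step from compound 2 to compound 3 is therefore expected to stay within the scatter, a 1.4-fold higher number from compound 2 to compound 3 (0.13 log units; within the scatter). Compound 3 is estimated at 90 nM, with a range from 30 nM to 300 nM.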

Compound 3, inhibition constant: 35 nM
Beside the measured number, compound 3's estimate is 2.6-fold (0.41 log units) above it; measured number inside the range.
By their numbers in this assay, from the lowest: compounds 3, 2 and 1 (each within the scatter of the next, the first and the last beyond it).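

Shortening the chain, with phenyl in place of benzyl on a saturated chain carbon, three bonds along the chain from an amine nitrogen, gives a step in this assay (a 1.9-fold lower number from compound 2 to compound 3 (0.28 log units; within the scatter)). For the compounds shown here, this is the first measured look at the chain length, and this change does not stand clear of the usual spread of repeated measurements. The step therefore shows that, with the methyl on the nitrogen in place, this shorter chain and the longer one cannot be told apart here, and no measured evidence bears on the result.

Still open, as far as these compounds go, is how a longer chain, or a chlorine or methoxy group on the phenyl ring, would read in this test. Also open, from the compounds shown here alone, is whether hydrogen in place of the methyl would matter on the shorter chain.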